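A few compounds are considered here, and "the series" means these few. Any claim that something is new, unique, unknown or untested is made for them only; others in the source may bear on it.

Working notes on the series, antiproliferative read-out.

Compound 3 `C[Si](C)(C)c1cn(C[C@H](O)[C@H]2OC(=O)C(OCc3ccccc3)=C2OCc2ccccc2)nn1` gives 31800 nM in a functional assay on HCT-116 cells (Homo sapiens) for antiproliferative activity, read by MTT assay, with a stated time of 72 h; on this read-out lower numbers stand for stronger inhibition and higher numbers for weaker inhibition. On the three numbers in hand it stands second highest. Its nearest neighbour is compound 2 `O=C1O[C@H]([C@@H](O)Cn2cc(-c3cccc(O)c3)nn2)C(OCc2ccccc2)=C1OCc1ccccc1`, which gives 42900 nM; the step between them, a 1.3-fold lower number from compound 2 to compound 3 (0.13 log units; within the scatter), stays within the scatter. Its furthest neighbour is compound 1 `Cc1ccc(S(=O)(=O)NCc2cn(C[C@H](O)[C@H]3OC(=O)C(OCc4ccccc4)=C3OCc3ccccc3)nn2)cc1`, which gives 13100 nM; that step, a 2.4-fold higher number from compound 1 to compound 3 (0.39 log units; beyond the scatter), is beyond the scatter but modest. The remaining step, a 3.3-fold higher number from compound 1 to compound 2 (0.52 log units; beyond the scatter), marks the full spread of the measured set.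

Compound 4 `COc1ccc(-c2cn(C[C@H](O)[C@H]3OC(=O)C(OCc4ccccc4)=C3OCc3ccccc3)nn2)cc1` has not been measured in this assay. It differs from compound 3 by a group of 8 heavy atoms (7 carbon, 1 oxygen; one six-membered aromatic ring of carbon only) in place of a group of 4 heavy atoms (3 carbon, 1 silicon; no ring), on an aromatic carbon. The measured step that bears on this most directly is a 1.3-fold lower number from compound 2 to compound 3 (0.13 log units; within the scatter), where a six-membered aromatic ring was exchanged for the silicon-bearing group on an aromatic carbon and the read-out stayed within the scatter. The step of a 2.4-fold higher number from compound 1 to compound 3 (0.39 log units; beyond the scatter) exchanged a much larger group and is only loosely comparable. Putting an aromatic ring back in place of the silicon-bearing group is therefore expected to give no step beyond the scatter, with a slight lean toward a lower number. The estimate for compound 4 in this assay is 30000 nM, ranging from 12000 nM to 70000 nM. That estimate means a step of a 1.1-fold lower number from compound 3 to compound 4 (0.03 log units; within the scatter) is expected.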

Compound 4, half-maximal inhibitory concentration: > 100000 nM
Compound 4: only a limit was reported; the forecaster's own chance of this, stated with the estimate: 5%; middle value at least 3.3-fold (0.52 log units) from the limit.
By their numbers in this assay, from the lowest: compound 1; then compounds 3 and 2 (each within the scatter of the next). At a limit, above all of these: compound 4.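

In this assay compound 4 carries only a limit, not a number: the limit of > 100000 nM in this assay, at which 1 of the 4 values shown sits. Even so, all three new steps are readable and lie beyond the scatter, so 4-methoxyphenyl on this aromatic carbon of the five-membered ring stands apart from every group measured there earlier: an at least 3.1-fold higher number from compound 3 to compound 4 (0.49 log units; beyond the scatter), an at least 2.3-fold higher number from compound 2 to compound 4 (0.36 log units; beyond the scatter) and an at least 7.6-fold higher number from compound 1 to compound 4 (0.88 log units; beyond the scatter). The earlier step of a 1.3-fold lower number from compound 2 to compound 3 (0.13 log units; within the scatter) had suggested that a six-membered aromatic ring at this carbon reads much like the silicon-bearing group, but compound 2 and compound 4 both carry such a ring and still differ beyond the scatter, so the ring alone does not fix the read-out.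

The 3-hydroxyphenyl and 4-methoxyphenyl groups differ both in the group on the ring and in its place, and the compounds shown cannot separate the two. On these data alone, it also remains open how a plain phenyl, a 3-methoxyphenyl, a 4-hydroxyphenyl or an amine on a short chain would read at this carbon.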